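The source may hold more compounds than are shown below. What is called first, only, known or untested is meant among the compounds shown, and "the series" means these compounds.

Compound 1 `CC(=O)OCc1ccc2oc(=O)c(C(=O)Oc3cccc(Cl)c3)cc2c1` carries a 3-chlorophenoxy group on a carbonyl carbon of the shared core. In a functional assay on HT-1080 cells (Homo sapiens), read by transwell migration, with a stated time of 24 h, tested at 1 uM (a higher number here means a weaker effect of the compound at the concentration tested, a lower number a stronger effect), compound 1 gives 49.1%, the lowest of the three numbers shown, so among these compounds it produces the strongest effect on cell migration. Compound 2 `CC(=O)OCc1ccc2oc(=O)c(C(=O)N(C)c3ccccc3Cl)cc2c1` gives 62.8%, and compound 3 `CC(=O)OCc1ccc2oc(=O)c(C(=O)N(C)c3cccc(Cl)c3)cc2c1` gives 82.6%.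

Compound 4 `CC(=O)OCc1ccc2oc(=O)c(C(=O)N(C)c3ccc(Cl)cc3)cc2c1` has not yet been measured. It differs from compound 1 by (4-chlorophenyl)(methyl)amino in place of 3-chlorophenoxy on a carbonyl carbon. Within the data shown here, two measured steps bear on this change, since both also replace the 3-chlorophenoxy group with a (methyl)amino group bearing a chlorophenyl ring on the carbonyl carbon: a number 13.7 percentage points higher from compound 1 to compound 2 (beyond the scatter) and a number 33.5 percentage points higher from compound 1 to compound 3 (beyond the scatter). The third step, a number 19.8 percentage points higher from compound 2 to compound 3 (beyond the scatter), shows that the placement of the chlorine on the ring attached to the amide-type nitrogen also shifts the number, in this case toward a weaker effect. Among the measured compounds shown here, no measured compound carries a 4-chlorophenyl group, so the position of compound 4 between these outcomes is uncertain. The expectation is nevertheless an upward step, with compound 4 estimated at 72%, within a range from 55% to 90%, which corresponds to an expected step of a number 22.9 percentage points higher from compound 1 to compound 4 (beyond the scatter).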

Compound 4, a percentage reported as activity, at one concentration (the size of the read-out at that concentration, not a potency): 98.6%
Beside the measured number, compound 4's estimate is 26.6 percentage points below it; measured number outside the range, above it.
By their numbers in this assay, from the lowest: compound 1; then compound 2; then compound 3; then compound 4.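

The change to (4-chlorophenyl)(methyl)amino on this carbonyl carbon gives the largest shift seen in this assay, a number 49.5 percentage points higher from compound 1 to compound 4 (beyond the scatter), so compound 4 shows the weakest effect of the four. Among the amide-type compounds, moving the chlorine again raises the number, a number 16 percentage points higher from compound 3 to compound 4 (beyond the scatter) and a number 35.8 percentage points higher from compound 2 to compound 4 (beyond the scatter), which completes a rising order from the 2-chlorophenyl group through the 3-chlorophenyl group to the 4-chlorophenyl group, with no compound here going against it. No measurement shown here explains why the place of the chlorine matters so much in this series.

The (methyl)amino link and the place of the chlorine remain tied together, since a 2-chlorophenoxy or a 4-chlorophenoxy group on the same carbonyl carbon would be needed to show whether the order holds without that nitrogen. Going by these compounds, it also remains open how the number would respond to an amide hydrogen in place of the methyl group, or to a methoxy group or a fluorine in place of the chlorine on the ring.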